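A Single Ring Stereocentre Flipped in an Endoperoxide Acid

This account rests on a few compounds, and the source may have more. Where it says the series, first, only, none or still open, it means among the compounds named here.

Four compounds share a cyclic peroxide carrying a short acid or ester side chain. In a functional assay on SK-MEL-5 cells (Homo sapiens) for inhibition (on this read-out lower numbers stand for stronger inhibition of growth and higher numbers for weaker inhibition of growth), compound 2, `C=C1CCC[C@H]2[C@](C)(CC[C@]3(C)CC[C@H]([C@@H](C)C(=O)O)OO3)[C@@H](C)CC[C@]12C`, gives 2680 nM. Among the measured compounds shown here, compound 2 is the only compound here with an actual number; the two others reached only a limit of this assay. Compound 1, `C=C1CCCC(C)(C)C1(O)CC/C(C)=C/CC[C@]1(C)CC[C@@H]([C@@H](C)C(=O)OC)OO1`, is the methyl ester with a hydroxylated, opened core, and in this assay it gives > 17500 nM, which is a limit. Compound 3, `C=C1CCCC(C)(C)C1CC[C@]1(C)CC[C@@H]([C@@H](C)C(=O)O)OO1`, is the free acid on a simpler core, and in this assay it gives > 10000 nM, also a limit. Compound 4, `C=C1CCC[C@H]2[C@](C)(CC[C@]3(C)CC[C@@H]([C@@H](C)C(=O)O)OO3)[C@@H](C)CC[C@]12C`, is not yet measured. It is related to compound 2 by the two compounds have the same atoms and bonds and differ only in configuration as drawn: 1 of 7 stereo elements differ; a stereocentre at a saturated ring carbon is drawn R in compound 2 and S in compound 4. For the measured compounds named here, no measured pair here differs in a single place, so no step size from this set can guide the expectation; a change of configuration at one ring carbon leaves the atoms and bonds untouched. The expectation is that in this assay the step from compound 2 to compound 4 is a 1.7-fold higher number from compound 2 to compound 4 (0.23 log units; within the scatter), a modest weakening that may not exceed the usual scatter. Compound 4 is therefore estimated at 4500 nM, with a range from 1200 nM to 17000 nM.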

Compound 4, concentration for 50% growth inhibition: 1940 nM
Beside the measured number, compound 4's estimate is 2.3-fold (0.37 log units) above it; the range from low to high includes it.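

In this assay, inverting this one saturated ring carbon gives a 1.4-fold lower number from compound 2 to compound 4 (0.14 log units; within the scatter), so the read-out does not separate the two arrangements at this position. Among the compounds shown here, this is the first pair in the set that differs in a single place, which means the configuration at this ring carbon can be read on its own, with every other part of the structure held the same: the fact that compounds 2 and 4 differ only in the configuration as drawn Compound 4 also gives the set a second actual number on the shared core, and at this position the ring carbon can be drawn either way without a change that stands out from the usual variation between repeated measurements.

Still open, on these data alone, is what the other stereo elements contribute, and whether an amide or a primary alcohol in place of the carboxylic acid on this core would shift the number. Compound 1 and compound 3 do not settle either question: each differs from compound 2 in more than one place, and each reached only a limit of the assay rather than an actual number.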